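The source may report more compounds than this note shows. Statements on the series, on what has been measured and on what is new or still open speak of the compounds shown alone.

Working notes on the series.

Compound 1 `CC(C)CNC(=C\C(=O)/C=C/c1ccc(O)cc1)/C=C/c1ccc(O)cc1` carries isobutyl on the amine nitrogen and two free phenols. In a functional assay on CHO-K1 cells (Cricetulus griseus) for inhibition, read by sulforhodamine B assay, with a stated time of 72 h (on this read-out lower numbers stand for stronger inhibition and higher numbers for weaker inhibition), compound 1 gives 23700 nM. Compound 3 `CCC(C)NC(=C\C(=O)/C=C/c1ccc(O)cc1)/C=C/c1ccc(O)cc1` differs from compound 1 only by sec-butyl in place of isobutyl on an amine nitrogen. In this assay compound 3 gives 15100 nM. The step of a 1.6-fold lower number from compound 1 to compound 3 (0.20 log units; within the scatter) is small and sits inside the usual spread of repeated measurements.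

Compound 2 `COc1cc(/C=C/C(=O)/C=C(/C=C/c2ccc(OC(C)=O)c(OC)c2)NCC(C)C)ccc1OC(C)=O` keeps the isobutyl amine of compound 1 but has a different core; how the two cores differ is not broken down here. In this assay compound 2 reaches only a limit, > 25000 nM, so no number is known for it. This is the same situation as the limit of > 25000 nM in this assay, at which 1 of the 3 values shown sits.

Compound 4 `CCC(C)NC(=C\C(=O)/C=C/c1ccc(OC(C)=O)c(OC)c1)/C=C/c1ccc(OC(C)=O)c(OC)c1` has not yet been measured in this assay. It differs from compound 2 by sec-butyl in place of isobutyl on an amine nitrogen, the same change that takes compound 1 to compound 3, and the surroundings of the nitrogen read the same in both pairs.

Since the measured step of a 1.6-fold lower number from compound 1 to compound 3 (0.20 log units; within the scatter) stayed within the scatter, and since compound 2 shows only a limit, compound 4 is expected to remain near or beyond that limit as well. The step from compound 2 to compound 4 is estimated as a step that the limit leaves unreadable from compound 2 to compound 4. For compound 4 the expected value is 30000 nM, with a range from 15000 nM to 80000 nM.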

Compound 4, half-maximal inhibitory concentration: > 25000 nM
Compound 4: no number, only a limit (the forecaster's own chance of this, stated with the estimate: 65%); the middle value does not contradict the limit.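

In this assay compound 4 gives > 25000 nM, which is a limit and not a number. Compound 2 also stands only at a limit, so the step from compound 2 to compound 4 cannot be read: the limit of > 25000 nM in this assay, at which 2 of the 4 values shown sit.

The compounds shown leave open whether sec-butyl in place of isobutyl on an amine nitrogen makes any difference on the core of compound 2.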